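Swapping hydroxy for fluoro in a cytotoxicity series

The source may hold more compounds than are shown below. What is called first, only, known or untested is meant among the compounds shown, and "the series" means these compounds.

Compound 1 `COc1ccc([C@H]2CC(C)(O)[C@@H]3CC[C@@H](C)C[C@H]3O2)cc1` and compound 2 `COc1ccc(OC)c([C@H]2CC(C)(O)[C@@H]3CC[C@@H](C)C[C@H]3O2)c1` share a core that carries a hydroxy group on a saturated ring carbon; the difference between the two cores is not broken down here. In an ADME assay on MDCK cells (Canis lupus familiaris) for cytotoxicity, read by MTT assay, with a stated time of 48 h (a higher number here means that more compound is tolerated, a lower number that less compound is tolerated), compound 1 gives 689000 nM, and compound 2 gives 512000 nM, a gap that lies within the scatter of this assay. Compound 3 `COc1ccc([C@H]2CC(C)(F)[C@@H]3CC[C@@H](C)C[C@H]3O2)cc1` is the hydroxy-to-fluoro counterpart of compound 1, with the change (fluoro in place of hydroxy on a saturated ring carbon), and in this assay compound 3 gives 171000 nM, making a 4.0-fold lower number from compound 1 to compound 3 (0.61 log units; beyond the scatter). Compound 4 `COc1ccc(OC)c([C@H]2CC(C)(F)[C@@H]3CC[C@@H](C)C[C@H]3O2)c1` carries the same kind of change on the core of compound 2, (fluoro in place of hydroxy on a saturated ring carbon); around the place, the ring atom that bears a large group in compound 4 is described as bearing a group of 8 heavy atoms in compound 3. Because the earlier step of a 4.0-fold lower number from compound 1 to compound 3 (0.61 log units; beyond the scatter) was modest and the two hydroxy parents differ only within the scatter, a step of similar size is expected here, a 4.0-fold lower number from compound 2 to compound 4 (0.60 log units; beyond the scatter). Compound 4 is therefore estimated to give 128000 nM in this assay, most likely between 60000 nM and 270000 nM.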

Compound 4, half-maximal cytotoxic concentration: 37000 nM
Beside the measured number, compound 4's estimate is 3.5-fold (0.54 log units) above it; the whole stated range lies above it.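

In this assay, putting fluoro in place of hydroxy on the core of compound 2 gives a 14-fold lower number from compound 2 to compound 4 (1.14 log units; beyond the scatter). The direction of the step carries over from one core to the other, but its size does not: the same change on two cores in this assay, a 4.0-fold lower number (0.61 log units; beyond the scatter) from compound 1 to compound 3 and a 14-fold lower number (1.14 log units; beyond the scatter) from compound 2 to compound 4, 3.4-fold (0.54 log units) apart, beyond the scatter of two such steps So a step measured on one core gave a poor guide to the size of the same change on the other, although these two pairs show neither which feature of the cores lies behind the gap nor how the change would behave on a third core.

From the compounds shown here alone, only hydroxy and fluoro appear on this saturated ring carbon, so it remains open how an amine, a chloro group or a longer chain there would compare on either core. Going by these compounds, it also remains open whether any such group would show the same dependence on the core, or whether this gap is particular to the step from hydroxy to fluoro.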